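The compounds below may be only part of what the source reports. "The series", "measured", "known", "first", "only" and "open" are said of these compounds alone.

Measured compounds:
compound 1 `Cc1ccc(-c2ccc(C(=O)N=C(N)N)cc2S(C)(=O)=O)cc1` — 100 nM
compound 2 `CS(=O)(=O)c1cc(C(=O)N=C(N)N)ccc1C#N` — 140 nM
compound 3 `Cc1cc(C#N)c(S(C)(=O)=O)cc1C(=O)N=C(N)N` — 70 nM

On a functional assay for inhibition of sodium/hydrogen exchanger (Oryctolagus cuniculus) (on this read-out higher numbers stand for weaker inhibition and lower numbers for stronger inhibition), compound 2 gives the top number of the three, yet neither gap to its neighbours goes beyond the scatter: a 1.4-fold higher number from compound 1 to compound 2 (0.15 log units; within the scatter), and a 2.0-fold lower number from compound 2 to compound 3 (0.30 log units; within the scatter). The three measured compounds therefore form one cluster on this assay rather than a ranked series.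

Compound 4 `Cc1ccc(C(=O)N=C(N)N)cc1S(C)(=O)=O` is the unmeasured member of the set. It differs from compound 2 in one place: methyl in place of cyano on an aromatic carbon. Among the measured compounds shown here, no measured pair shows exactly this exchange. The two steps that come closest both touch the same region of the shared core. The step from compound 1 to compound 2 brought the cyano group in, and it stayed within the scatter. The step from compound 2 to compound 3 added a methyl group on an aromatic carbon, and it also stayed within the scatter. Both neighbouring changes left this assay essentially unmoved, so removing the cyano group and placing a methyl group at that carbon is expected to produce no step beyond the scatter in either direction.

Compound 4 is therefore estimated at 110 nM, with a range from 50 nM to 250 nM. That estimate corresponds to a step of a 1.3-fold lower number from compound 2 to compound 4 (0.10 log units; within the scatter).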

Compound 4, half-maximal inhibitory concentration: 210 nM
For compound 4 the middle estimate is 1.9-fold (0.28 log units) below the measured one; measured number inside the range.
By their numbers in this assay, from the lowest: compounds 3, 1, 2 and 4 (each within the scatter of the next, the first and the last beyond it).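

Among the compounds shown here, on this assay, the direct exchange of cyano for methyl on the aromatic carbon ortho to the methylsulfonyl group gives a 1.5-fold higher number from compound 2 to compound 4 (0.18 log units; within the scatter), so this change, which no earlier pair showed, does not separate the two groups. For the compounds shown here, replacing 4-methylphenyl with methyl at the same carbon gives a 2.1-fold higher number from compound 1 to compound 4 (0.32 log units; beyond the scatter), the first single-place step in this set to pass the scatter, although only modestly; the position is therefore not wholly indifferent to its substituent, even though compound 2, with its cyano group, stays within the scatter of both compound 1 and compound 4. Nothing available here accounts for either step.

The three groups compared at this carbon leave open whether an amine, a carboxylic acid or a longer chain such as n-butyl would stay within the scatter of these compounds or produce a larger step. On these data alone, it also remains open whether the modest step between compound 1 and compound 4 would extend to other aryl groups at this carbon, such as unsubstituted phenyl.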